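A few compounds are considered here, and "the series" means these few. Any claim that something is new, unique, unknown or untested is made for them only; others in the source may bear on it.

Working notes on the series. Compound 1 `Nc1scc(CN2CCN(c3cccc(Cl)c3Cl)CC2)c1C(=O)c1ccc(Cl)cc1` and compound 2 `Nc1scc(CN2CCN(c3ccc(F)cc3Cl)CC2)c1C(=O)c1ccc(Cl)cc1` share the same core and differ only in the group on the amine nitrogen in a ring. In an assay on CHO cells for displacement of a labelled ligand from adenosine receptor A1 (Homo sapiens), read by scintillation counting, with a stated time of 120 min, tested at 10 uM (a higher number here means more inhibition at the concentration tested (going by the name of the read-out), a lower number less inhibition), compound 1 gives 2%. In this assay, going by the values given here, compound 2 gives 0%, the lowest of the two numbers measured so far, though the two values lie within the scatter of each other. Among the compounds with values here, the single step seen to date, a number 2 percentage points lower from compound 1 to compound 2 (within the scatter), shows no effect beyond the scatter from exchanging the aryl group at this position. Compound 3 `Nc1scc(CN2CCN(c3c(F)cc(F)cc3F)CC2)c1C(=O)c1ccc(Cl)cc1` carries 2,4,6-trifluorophenyl in place of 2-chloro-4-fluorophenyl on an amine nitrogen in a ring. Within the data shown here, the only measured step that bears on this change is the one from compound 1 to compound 2, which stayed within the scatter, so no step beyond the scatter is expected in this assay. For compound 3 the expected step is a number 1 percentage points higher from compound 2 to compound 3 (within the scatter). Compound 3 is estimated at 1% in this assay, with a range from -8% to 12%.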

Compound 3, a percentage reported as inhibition, at one concentration (the size of the read-out at that concentration, not a potency): 0%
Compound 3: middle estimate off by 1 percentage points, on the high side, within the range that was stated.
By their numbers in this assay, from the lowest: compounds 2, 3 and 1 (each within the scatter of the next).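

In this assay the exchange at this position gives no change at the digits printed from compound 2 to compound 3 (within the scatter), and the wider exchange gives a number 2 percentage points lower from compound 1 to compound 3 (within the scatter). The 2,4,6-trifluorophenyl group carries fluorine alone, unlike the two chlorine-bearing aryl groups before it, yet all three remain within the scatter of one another, so the earlier flat step now holds for a third halogenated phenyl on the amine nitrogen in a ring. Nothing available gives a reason for this flat result. From the compounds shown here alone, all three groups are halogenated phenyl rings, so it stays open whether an aryl group bearing an amine or a carboxylic acid, or a longer chain in place of the aryl group, would give a step beyond the scatter. Since all three numbers lie so close together, these compounds also cannot separate the effects of the individual halogens.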